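This account rests on a few compounds, and the source may have more. Where it says the series, first, only, none or still open, it means among the compounds named here.

In a functional assay on K562 cells (Homo sapiens) for cytotoxicity, read by MTT assay, with a stated time of 48 h (on this read-out lower numbers stand for stronger inhibition and higher numbers for weaker inhibition), compound 1 (`COc1ccc(-c2c[nH]c(=O)n2-c2cc(OC)c(OC)c(OC)c2)cc1N`) gives 49200 nM. Compound 2 (`COc1cc(-n2c(-c3ccccc3)cn(C(C)=O)c2=O)cc(OC)c1OC`) reads > 50000 nM, which is a limit of the assay and not a number. Compound 3 (`COc1ccc(-c2cn(C(C)=O)c(=O)n2-c2cc(OC)c(OC)c(OC)c2)cc1`) differs from compound 2 by methoxy in place of hydrogen on an aromatic carbon, with methoxy in place of hydrogen on an aromatic carbon. Among the measured compounds shown here, no measured step isolates this change. A modest move towards stronger inhibition in this assay is expected, giving an estimated at least 4.1-fold lower number from compound 2 to compound 3 (0.61 log units; beyond the scatter). That expectation stays cautious, as compound 1 sits at only 49200 nM. For compound 3 the estimated value is 12000 nM, with an expected range of 800 nM to 50000 nM.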

Compound 3, half-maximal inhibitory concentration: 200 nM
Estimate against measurement, compound 3: 60-fold (1.78 log units) above; the measured number lies below the stated range.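

Methoxy in place of hydrogen, on an aromatic carbon para to a large group, gives an at least 250-fold lower number from compound 2 to compound 3 (2.39 log units; beyond the scatter) in this assay. Among the compounds shown here, no earlier compound showed that this position responds, and the phenyl to 4-methoxyphenyl change is the first single change here to lead away from the limit. Compound 2 stands at a limit and not a number, so the step is a bound: the limit of > 50000 nM in this assay, at which 1 of the 3 values shown sits.

Whether methoxy itself is required stays open, as neither a hydroxyl, an ethoxy nor a fluorine at this position appears among the compounds shown. Compound 1 and compound 3 differ in more than one place, which leaves the role of the acetyl group unresolved.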